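Compound 3: replacing tert-butyl with 2-oxopropyl

The compounds below may be only part of what the source reports. "The series", "measured", "known", "first", "only" and "open" are said of these compounds alone.

Values in a functional assay on the whole organism (trachea) for inhibition, with Cavia porcellus as the target (on this read-out lower numbers stand for an effect already at smaller amounts and higher numbers for an effect only at larger amounts of compound), so far
- Compound 1 `COc1ccccc1OCC1SCCN1C(=O)C[S+](C)[O-]` gives 10 mg/kg
- Compound 2 `COc1ccccc1OCC1SCCN1C(=O)C(C)(C)C` gives 24 mg/kg

Among the compounds with values here, of these two numbers, compound 2 has the higher, with compound 1 as its only neighbour. Compound 3 `COc1ccccc1OCC1SCCN1C(=O)CC(C)=O` has not yet been measured. It carries 2-oxopropyl in place of tert-butyl on a carbonyl carbon and otherwise matches compound 2. Within the data shown here, one measured step bears on this change: a 2.4-fold higher number from compound 1 to compound 2 (0.38 log units; beyond the scatter), a modest step that also exchanges the group on that carbonyl carbon. Among the measured compounds shown here, it is a single pair, and no compound with 2-oxopropyl has a value yet, so the guidance is thin. Like the group in compound 1, 2-oxopropyl contains oxygen and no ring, so a partial move back toward compound 1 at 10 mg/kg is expected, though not a full return. The expected step in this assay is a 1.7-fold lower number from compound 2 to compound 3 (0.23 log units; within the scatter), smaller than the measured one. For compound 3 the estimated value is 14 mg/kg, with an expected range from 6 mg/kg to 32 mg/kg.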

Compound 3, dose for half-maximal effect: 26 mg/kg
Beside the measured number, compound 3's estimate is 1.9-fold (0.27 log units) below it, and the stated range covers the measured number.
By their numbers in this assay, from the lowest: compound 1; then compounds 2 and 3 (each within the scatter of the next).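

In this assay, putting 2-oxopropyl in place of tert-butyl on a carbonyl carbon gives a 1.1-fold higher number from compound 2 to compound 3 (0.03 log units; within the scatter), so at this position the change from an all-carbon group to one carrying a hydrogen-bond acceptor does not separate compound 2 from compound 3. Within the data shown here, compound 1 remains apart, with a 2.6-fold higher number from compound 1 to compound 3 (0.41 log units; beyond the scatter), which shows that an oxygen-containing group without a ring is not enough on its own to match compound 1, and points instead to the one part of that group that compound 3 lacks, its sulfur, as the place where the difference is tied to the structure, though only as a correlation across these compounds. No measurement shown here explains why the three groups fall as they do.

On these data alone, it remains open whether a sulfur-containing chain without the oxygen on sulfur, such as a methylthiomethyl group, would fall with compound 1 or with compound 2 and compound 3. Also open is how an amine, a carboxylic acid or a longer chain on this carbonyl carbon would read out in this assay, since the compounds shown span only small groups without a ring.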